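The source may report more compounds than this note shows. Statements on the series, on what has been measured and on what is new or still open speak of the compounds shown alone.

Compound 3 `CC1(c2ccccc2)CC(=O)C(C2CC(c3ccc(OCc4ccc(C(F)(F)F)cc4)cc3)Cc3ccccc32)=C(O)O1` stands at the limit in a functional assay on XF498 cells (Homo sapiens) for inhibition, with a stated time of 72 h; a lower number here means a stronger inhibitor, a higher number a weaker inhibitor: compound 3 gives > 10000 nM, a limit of the assay and not a number. Compound 1 `COc1ccc(C2Cc3ccccc3C(C3=C(O)OCCC3=O)C2)cc1` sits at the same limit, since in this assay compound 1 gives > 10000 nM. Among the measured compounds shown here, the one numerical value in the set belongs to compound 2 `CC1(c2ccccc2)CC(=O)C(C2CC(c3ccc(-c4ccc(Br)cc4)cc3)Cc3ccccc32)=C(O)O1`, which in this assay gives 1360 nM. For the measured compounds named here, the only measured step, an at least 7.3-fold higher number from compound 2 to compound 3 (0.86 log units; beyond the scatter), is an exchange of the aromatic substituent and moves the number up to the limit (the limit of > 10000 nM in this assay, at which 2 of the 3 values shown sit).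

Compound 4 `COc1ccc(C2Cc3ccccc3C(C3=C(O)OC(C)(c4ccccc4)CC3=O)C2)cc1` differs from compound 3 by hydrogen in place of 4-(trifluoromethyl)phenyl on a saturated chain carbon bound to an oxygen on an aromatic ring. Going by the values given here, no measured step bears directly on this change; the step from compound 2 to compound 3 concerns a different exchange on the same aromatic carbon and ends at a limit, so it sets no direction for a further cut of that substituent. Compound 1 shares the methoxy group of compound 4 but differs in the lactone portion, and its value is itself a limit. Compound 4 is therefore expected to remain at or beyond the limit, the step that the limit leaves unreadable from compound 3 to compound 4 being estimated as none beyond the scatter. The estimate for compound 4 in this assay is 15000 nM, with a range from 4000 nM to 60000 nM.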

Compound 4, half-maximal inhibitory concentration: > 10000 nM
Compound 4 gave a limit, no number (the forecaster's own chance of this, stated with the estimate: 70%); the middle value lies beyond the limit too.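

In this assay compound 4 gives > 10000 nM, a limit of the assay and not a number. Methoxy in place of 4-bromophenyl on the aromatic carbon gives an at least 7.3-fold higher number from compound 2 to compound 4 (0.86 log units; beyond the scatter), which joins the earlier exchange with (4-(trifluoromethyl)benzyl)oxy in the same place, an at least 7.3-fold higher number from compound 2 to compound 3 (0.86 log units; beyond the scatter), so two different oxygen-linked groups there now both lose the measurable value held by compound 2. The steps between the limits cannot be read, so removing 4-(trifluoromethyl)phenyl from compound 3 has no size that can be stated, and the data set is now mostly limits: the limit of > 10000 nM in this assay, at which 3 of the 4 values shown sit.

Going by these compounds, it remains open whether the measurable value of compound 2 depends on the bromine or on the second phenyl ring, a question that a plain phenyl or a 4-chlorophenyl in that place would address, while a morpholine or a carboxylic acid there would test a quite different kind of group. Among the compounds shown here, with compound 2 as the only compound giving a number, no order among the remaining compounds can be read, and how far each lies past the limit stays unknown.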